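Hexyl-to-hydrogen shortening across two related cores

This account rests on a few compounds, and the source may have more. Where it says the series, first, only, none or still open, it means among the compounds named here.

Compound 2 `CCCCCCCCCCOC(=N)NC(=N)Nc1ccc(Cl)cc1` and compound 1 `CCCCOC(=N)NC(=N)Nc1ccc(Cl)cc1` share one core. In a physicochemical assay for lipophilicity, in phosphate buffer, measured as octanol-water partition, at pH 11.5 (a higher number here means a more lipophilic compound, a lower number a more polar compound), compound 2 gives 6.32, and compound 1 gives 3.32. The change between them, (hydrogen in place of hexyl on a saturated chain carbon, four bonds along the chain from an oxygen on an unsaturated carbon), produced a number 3.00 log units lower from compound 2 to compound 1 (beyond the scatter). Compound 3 `CCCCCCCCCCNC(=N)NC(=N)Nc1ccc(Cl)cc1` carries a second core; the difference between the two cores is not broken down here. In this assay compound 3 gives 6.13, which against compound 2 lies within the scatter. Compound 4 `CCCCNC(=N)NC(=N)Nc1ccc(Cl)cc1` has not yet been measured. It differs from compound 3 by hydrogen in place of hexyl on a saturated chain carbon, four bonds along the chain from an amine nitrogen. This is the same kind of change as that from compound 2 to compound 1, but not the same: there the place was four bonds along the chain from an oxygen on an unsaturated carbon, here it is four bonds along the chain from an amine nitrogen. Among the compounds with values here, only one earlier instance exists, so the expectation rests on that alone. The step expected is a number 3.00 log units lower from compound 3 to compound 4 (beyond the scatter), because compound 3 stands at 6.13 and the earlier shortening gave a number 3.00 log units lower from compound 2 to compound 1 (beyond the scatter). Compound 4 is therefore estimated at 3.13, with a range from 2.7 to 3.55.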

Compound 4, partition coefficient: 3.13
Compound 4: the middle estimate sits on the measured number at the digits printed; measured number inside the range.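

In this assay the shortening of hexyl to hydrogen gives a number 3.00 log units lower from compound 3 to compound 4 (beyond the scatter), matching a number 3.00 log units lower from compound 2 to compound 1 (beyond the scatter), so on these two cores the change carries over at the same size. Butylamino in place of butoxy gives a number 0.19 log units lower from compound 1 to compound 4 (within the scatter), so the choice of core does not separate this shorter pair in this assay. This rests on a single pair from each core and sets no rule for the series beyond these four compounds, and nothing available explains why the two steps match.

The compounds shown leave open whether the step would hold at the same size on a third core, such as one carrying a sulfur atom in place of the oxygen or the amine nitrogen. Also open, going by these compounds, is how the number runs at chain lengths other than these two, or when the chain is branched or ends in a hydroxyl group or a carboxylic acid.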